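Chloro to hexylamino: working notes toward compound 3

A few compounds are considered here, and "the series" means these few. Any claim that something is new, unique, unknown or untested is made for them only; others in the source may bear on it.

Measured so far:
compound 1, `C=CCOc1ccc(C(=O)Nc2cccc(Cl)n2)cc1`, gives > 100000 nM in an in vitro assay on HEK-tsA201 cells for antagonist activity at Neuronal acetylcholine receptor; alpha3/beta4 (Homo sapiens), read by fluorescence and calcium flux; on this read-out higher numbers stand for weaker inhibition and lower numbers for stronger inhibition
compound 2, `CCCOc1ccc(C(=O)Nc2cccc(Cl)n2)cc1`, gives > 100000 nM in this assay

Compound 2 stands only at a limit of this assay, > 100000 nM, not at a number. Compound 1 likewise reports only a limit, > 100000 nM. Among the measured compounds shown here, both values sit at the same limit (the limit of > 100000 nM in this assay, at which 2 of the 2 values shown sit), so the one step between measured compounds, a step that the two limits leave unreadable from compound 1 to compound 2, cannot be read. Compound 3, `CCCCCCNc1cccc(NC(=O)c2ccc(OCCC)cc2)n1`, differs from compound 2 by hexylamino in place of chloro on an aromatic carbon. For the measured compounds named here, no measured step bears readably on this change, and the series gives no number from which to project. The step from compound 2 to compound 3 is therefore expected to be a number no higher from compound 2 to compound 3 (the limit leaves the size open), with the outcome most likely again a limit. Compound 3 is estimated at 100000 nM in this assay, within 20000 nM to 300000 nM.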

Compound 3, half-maximal inhibitory concentration: > 100000 nM
Compound 3: a limit, no number; the forecaster's own chance of this, stated with the estimate: 70%; the middle value sits exactly at the limit.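

No new step can be read between compound 2 and compound 3, and the series still holds no number, only one shared limit: the limit of > 100000 nM in this assay, at which 3 of the 3 values shown sit. The compounds shown leave open whether hexylamino in place of chloro changes inhibition at all, and what change on the shared core would bring a value inside the range of the read-out.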